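A few compounds are considered here, and "the series" means these few. Any claim that something is new, unique, unknown or untested is made for them only; others in the source may bear on it.

Measured in a functional assay (plasma) for inhibition, with Rattus norvegicus as the target; on this read-out lower numbers stand for stronger inhibition and higher numbers for weaker inhibition:
- Compound 1 `O=C(O)COc1cccc2c1CCC(COC(=O)N(c1ccccc1)c1ccccc1)=C2`: > 10000 nM (a limit)
- Compound 2 `O=C(O)COc1cccc2c1CC[C@](O)(COC(=O)N(c1ccccc1)c1ccccc1)[C@H]2O`: > 10000 nM (a limit)

Neither result is an exact number, and the evidence so far is the limit of > 10000 nM in this assay, at which 2 of the 2 values shown sit. Compound 2 therefore stands at a limit of this assay, with no exact value. Compound 3 `O=C(O)COc1cccc2c1CC[C@](O)(COC(=O)N(c1ccccc1)c1ccccc1)[C@@H]2O` has the same atoms and bonds as compound 2, and the change is this: the two compounds have the same atoms and bonds and differ only in configuration as drawn: 1 of 2 stereo elements differ; a stereocentre at a saturated ring carbon is drawn S in compound 2 and R in compound 3. Among the compounds with values here, no measured pair shows what such a change does in this assay. The expected a number no higher from compound 2 to compound 3 (the limit leaves the size open) is therefore none beyond the scatter, in either direction. For compound 3 the estimated value is 10000 nM, with an expected range from 3000 nM to 30000 nM.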

Compound 3, half-maximal inhibitory concentration: 7400 nM
For compound 3 the middle estimate is 1.4-fold (0.13 log units) above the measured one; measured number inside the range.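

In this assay compound 3 is the only one of the three with an exact number, 7400 nM, so this stereocentre at a saturated ring carbon can now be read against a real value. The step is an at least 1.3-fold lower number from compound 2 to compound 3 (0.13 log units; that floor lies within the scatter), so no true gain is established. Any gap has one possible source: the fact that compounds 2 and 3 differ only in the configuration as drawn.

Going by these compounds, compound 2 has only a limit, so the real size of the step stays open. Also open, on these data alone, is what an amine in place of the carboxylic acid would do to this number.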